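Flipping Two Ring Centres in a Mannosidase Assay Series

The source may hold more compounds than are shown below. What is called first, only, known or untested is meant among the compounds shown, and "the series" means these compounds.

Of the compounds shown here, three have so far been tested in an assay on isolated protein for inhibition of alpha-mannosidase (Canavalia ensiformis), with stated times of 5 min and 20 min, tested at 1 mM; a higher number here means more inhibition at the concentration tested (going by the name of the read-out), a lower number less inhibition. Compound 1 `[N-]=[N+]=NC[C@H]1NC[C@@H](O)[C@H]1O` gives 43%, compound 3 `O=C(NC[C@@H]1NC[C@@H](O)[C@H]1O)c1ccccc1` gives 71%, and compound 2 `O[C@@H]1[C@@H](c2cn(Cc3ccccc3)nn2)NC[C@@H]1O` gives 30%. Among these three numbers compound 2 stands lowest: its nearest neighbour is compound 1, whose number lies higher by more than the usual scatter, and the furthest is compound 3, whose number lies higher still, well beyond the scatter.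

Compound 4 `O[C@@H]1[C@H](O)CN[C@@H]1c1cn(Cc2ccccc2)nn1` has not yet been measured. It differs from compound 2 in this way: the two compounds have the same atoms and bonds and differ only in configuration as drawn: 2 of 3 stereo elements differ; a stereocentre at a saturated ring carbon is drawn R in compound 2 and S in compound 4; a stereocentre at a saturated ring carbon is drawn S in compound 2 and R in compound 4. Nothing is added and nothing is removed, so the comparison rests entirely on how the same groups are arranged around the ring.

Within the data shown here, none of the three measured compounds differ from one another only in configuration, so no measured step shows what such a rearrangement does here. Turning two centres of the ring could move the number in either direction, and a shift beyond the scatter would not be surprising. As a working estimate the step of a number 2 percentage points higher from compound 2 to compound 4 (within the scatter) is expected to be small, with wide uncertainty around it. Compound 4 is estimated at 32%, within a range from 10% to 60%.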

Compound 4, a percentage reported as inhibition, at one concentration (the size of the read-out at that concentration, not a potency): "not active" (no number reported)
No number was reported for compound 4; the estimate stays without a comparison.
By their numbers in this assay, from the lowest: compound 2; then compound 1; then compound 3.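

Among these compounds, compound 4 is reported only as "not active", without a number, so no step from compound 2 to compound 4 can be read. The compounds shown leave open how far turning two ring centres moves the inhibition away from that of compound 2 at 30%.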